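Three Inactive Benzamides and a Methoxyphenyl Variant

This account rests on a few compounds, and the source may have more. Where it says the series, first, only, none or still open, it means among the compounds named here.

Compound 1 `O=C(Nc1ccc(Sc2nc3ccccc3s2)cc1)c1cc(Br)cc(Br)c1O` was examined in an assay on isolated protein for inhibition of thiosulfate sulfurtransferase (Homo sapiens), with a stated time of 60 min, in the absence of a further agent; a higher number here means a weaker inhibitor, a lower number a stronger inhibitor. In this assay compound 1 returns only a limit, > 100000 nM, and no number. Compound 2 `COc1c(Br)cc(Br)cc1C(=O)Nc1ccccc1` likewise gives only a limit in this assay, > 100000 nM. Compound 3 `O=C(Nc1ccc(Sc2nc3ccccc3s2)c(Cl)c1)c1cccc(Br)c1O` also reaches only a limit in this assay, > 100000 nM. For the measured compounds named here, compound 1 therefore cannot be ranked against the other two: the limit of > 100000 nM in this assay, at which 3 of the 3 values shown sit, so all three stand together at the edge of what this assay can report, and no measured step between any pair of them exists.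

Compound 4 `COc1ccccc1C(=O)Nc1ccc(Sc2nc3ccccc3s2)cc1` has not yet been measured. It differs from compound 1 in one place (2-methoxyphenyl in place of 3,5-dibromo-2-hydroxyphenyl on a carbonyl carbon). Going by the values given here, no comparison between measured compounds bears directly on this change. Because (the limit of > 100000 nM in this assay, at which 3 of the 3 values shown sit), the expected step is a step that the limit leaves unreadable from compound 1 to compound 4, which is to say no movement beyond the scatter. Compound 4 is estimated at 150000 nM, within a range from 50000 nM to 500000 nM, with a strong chance that this assay again reports only a limit rather than a number.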

Compound 4, half-maximal inhibitory concentration: > 100000 nM
Compound 4 gave a limit, no number; the forecaster's own chance of this, stated with the estimate: 85%; the middle value is on the limit's open side.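

No new step can be read between compound 1 and compound 4, since each gives only a limit: the limit of > 100000 nM in this assay, at which 4 of the 4 values shown sit.

The compounds shown leave open whether any member of this series reaches a true number in this assay, and how 2-methoxyphenyl and 3,5-dibromo-2-hydroxyphenyl actually compare.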